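The compounds below may be only part of what the source reports. "The series", "measured", "known", "first", "only" and "open" are said of these compounds alone.

Measured compounds:
Compound 1 `O=[N+]([O-])c1cncn1CS(=O)(=O)NCCO` gives 2300000 nM in a functional assay on HCT-116 cells (Homo sapiens) for cytotoxicity, read by sulforhodamine B assay, with stated times of 4 h and 5 days; a higher number here means a weaker inhibitor, a lower number a stronger inhibitor.
Compound 2 `O=[N+]([O-])c1cncn1CCS(=O)(=O)NCCO` gives 5300000 nM in this assay.
Compound 3 `Cc1ncc([N+](=O)[O-])n1CCS(=O)(=O)NCCO` gives 400000 nM in this assay.

Compound 3 holds the lowest number of the three in this assay; compound 1 comes nearest to it and compound 2 lies furthest away, both gaps being beyond the scatter. For the measured compounds named here, the only single-point step among the measured compounds is the one a 13-fold lower number from compound 2 to compound 3 (1.12 log units; beyond the scatter), a methyl on an aromatic carbon of the shared core in place of a hydrogen. Compound 1 and compound 2 differ in the length of the chain between the core and the sulfonamide, and their two values show compound 1 with the lower number.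

Compound 4 `CCN(CC)CCNS(=O)(=O)CCn1c([N+](=O)[O-])cnc1C` has not yet been measured. It differs from compound 3 in that (diethylamino in place of hydroxy on a saturated chain carbon, two bonds along the chain from a sulfonamide nitrogen). None of the measured steps touches this end of the chain: the one listed step concerns the aromatic methyl, and the other pair concerns the chain length. Going by the values given here, there is therefore no measured step that bears directly on this change, and the expectation rests on compound 3 alone. The step of a 2.0-fold lower number from compound 3 to compound 4 (0.30 log units; within the scatter) is estimated to be modest and downward in number, well short of the size seen for the aromatic methyl. For compound 4 the expected value in this assay is 200000 nM, with a range from 50000 nM to 800000 nM.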

Compound 4, half-maximal inhibitory concentration: 1300000 nM
Compound 4: the middle estimate sits 6.5-fold (0.81 log units) below what was measured; measured number outside the range, above it.
By their numbers in this assay, from the lowest: compound 3; then compounds 4 and 1 (each within the scatter of the next); then compound 2.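

For the compounds shown here, the change from hydroxy to diethylamino, on a saturated chain carbon, two bonds along the chain from a sulfonamide nitrogen, gives the first reading at this end of the chain: in this assay it brings a 3.3-fold higher number from compound 3 to compound 4 (0.51 log units; beyond the scatter) and so shows that this end is not indifferent to what it carries. The number moves in the opposite direction to the aromatic methyl step, a 13-fold lower number from compound 2 to compound 3 (1.12 log units; beyond the scatter), and by a smaller amount, even though the entering group holds 5 heavy atoms where the leaving group holds 1 and no hydrogen-bond donor where the leaving group holds 1. Nothing available accounts for this rise, so the result stands as an observation without an explanation.

On these data alone, whether the rise goes with the loss of the hydroxy or with the arrival of the diethylamino group stays open, and a methoxy, a primary amine, a carboxylic acid or a longer chain at this place would help to separate the two. Also open, as far as these compounds go, is whether the same change would give a step of similar size on the core without the aromatic methyl, as in compound 2.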